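This account rests on a few compounds, and the source may have more. Where it says the series, first, only, none or still open, it means among the compounds named here.

Measured so far in a functional assay on NCI-H460 cells (Homo sapiens) for cytotoxicity, read by MTT assay, with a stated time of 72 h; a higher number here means a weaker inhibitor, a lower number a stronger inhibitor:
- compound 1 `CCN(CC)Cc1ccc2nc(NC(=O)N/N=C/c3cn(Cc4ccc(C)cc4)c4ccccc34)sc2c1`: 320 nM
- compound 2 `CCN(CC)Cc1ccc2nc(NC(=O)N/N=C/c3cn(Cc4ccc(Cl)cc4)c4ccccc34)sc2c1`: 370 nM
- compound 3 `CN(C)Cc1ccc2nc(NC(=O)N/N=C/c3cn(Cc4ccc(Cl)cc4)c4ccccc34)sc2c1`: 290 nM

All three numbers sit within the usual scatter of one another, so no ranking among them is claimed. The step of a 1.2-fold lower number from compound 2 to compound 1 (0.06 log units; within the scatter) corresponds to methyl in place of chloro on an aromatic carbon. The step of a 1.3-fold lower number from compound 2 to compound 3 (0.11 log units; within the scatter) corresponds to dimethylamino in place of diethylamino on a saturated chain carbon bound to an aromatic carbon, which is also how the core of compound 3 differs from the core of compound 2.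

Compound 4 `Cc1ccc(Cn2cc(/C=N/NC(=O)Nc3nc4ccc(CN(C)C)cc4s3)c3ccccc32)cc1` is not yet measured. It differs from compound 3 by methyl in place of chloro on an aromatic carbon. This is the same change as that from compound 2 to compound 1, made on the core of compound 3 rather than on the core of compound 2; the two places are described in the same words.

For compound 4 the expected step is a 1.2-fold lower number from compound 3 to compound 4 (0.06 log units; within the scatter), small and within scatter, because the measured step of a 1.2-fold lower number from compound 2 to compound 1 (0.06 log units; within the scatter) was small and within scatter. Compound 4 is therefore estimated at 250 nM in this assay, with a range from 130 nM to 480 nM.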

Compound 4, half-maximal inhibitory concentration: 200 nM
Compound 4: middle estimate off by 1.3-fold (0.10 log units), on the high side; measured number inside the range.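

In this assay, among the compounds shown here, methyl in place of chloro on the core of compound 3 gives a 1.5-fold lower number from compound 3 to compound 4 (0.16 log units; within the scatter), and this agrees with the same change on the other core: the same change on two cores in this assay, a 1.2-fold lower number (0.06 log units; within the scatter) from compound 2 to compound 1 and a 1.5-fold lower number (0.16 log units; within the scatter) from compound 3 to compound 4, 1.3-fold (0.10 log units) apart, within the scatter of two such steps Dimethylamino in place of diethylamino gives a 1.6-fold lower number from compound 1 to compound 4 (0.20 log units; within the scatter), which likewise agrees with its earlier counterpart: the same change on two cores in this assay, a 1.3-fold lower number (0.11 log units; within the scatter) from compound 2 to compound 3 and a 1.6-fold lower number (0.20 log units; within the scatter) from compound 1 to compound 4, 1.3-fold (0.10 log units) apart, within the scatter of two such steps Both changes therefore carry from one core to the other without a detectable difference, but all four steps lie within the scatter, so this shows only that small steps stayed small on these cores, not that either change moves the number in a real direction or that a change with a large step would carry over as well.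

Still open, going by these compounds, is what happens when a group other than chloro or methyl stands on the benzyl ring, such as methoxy or a carboxylic acid. Also open, on these data alone, is how a cyclic amine such as morpholine compares with dimethylamino and diethylamino on the side chain.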